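Removing the bromoacetyl group from a triazole chalcone

The compounds below may be only part of what the source reports. "The series", "measured", "known", "first", "only" and "open" are said of these compounds alone.

Measured compounds:
Compound 1 `O=C(CBr)Nc1ccc(C(=O)/C=C/c2cn(Cc3ccc(Br)cc3)nn2)cc1` gives 10100 nM in a functional assay on MCF7 cells (Homo sapiens) for inhibition, read by MTT assay; on this read-out lower numbers stand for stronger inhibition and higher numbers for weaker inhibition.
Compound 2 `CCCCCCCCn1cc(/C=C/C(=O)c2ccc(NC(=O)CBr)cc2)nn1` gives 12900 nM in this assay.
Compound 3 `CCCCCCCCn1cc(/C=C/C(=O)c2ccc(NC(=O)CN3CCN(c4ccccc4OC)CC3)cc2)nn1` gives 30000 nM in this assay.

On these numbers compound 2 stands second highest of three: compound 1 lies a little lower, within the scatter, while compound 3 lies higher, beyond it. Compound 4 `CCCCCCCCn1cc(/C=C/C(=O)c2ccc(N)cc2)nn1` differs from compound 2 by hydrogen in place of (bromomethyl)carbonyl on a nitrogen on an aromatic ring. Among the compounds with values here, the only measured step, a 1.3-fold higher number from compound 1 to compound 2 (0.11 log units; within the scatter), concerns the saturated chain carbon bound to the aromatic nitrogen, not the nitrogen on the aromatic ring, so it does not bear on this change. Within the data shown here, compound 3 carries a different group on that nitrogen and gives the highest of the three numbers, but no single-point step links it to compound 2. With nothing directly comparable, a modest rise is expected, a 1.9-fold higher number from compound 2 to compound 4 (0.29 log units; within the scatter). Compound 4 is therefore estimated at 25000 nM, with a range from 8000 nM to 80000 nM in this assay.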

Compound 4, half-maximal inhibitory concentration: 31000 nM
The estimate for compound 4 lay 1.2-fold (0.09 log units) below the measured number; the measured number falls inside the stated range.
By their numbers in this assay, from the lowest: compounds 1 and 2 (each within the scatter of the next); then compounds 3 and 4 (each within the scatter of the next).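

In this assay, within the data shown here, the nitrogen on the aromatic ring is the first place where a single change moves the number beyond the scatter: hydrogen in place of (bromomethyl)carbonyl gives a 2.4-fold higher number from compound 2 to compound 4 (0.38 log units; beyond the scatter) in a modest rise. The earlier step concerned the saturated chain carbon and stayed within the scatter. Nothing at hand accounts for this rise. The compounds shown leave open whether an acetyl group on that nitrogen, without the bromine, would stand with compound 2 or with compound 4. They also leave open whether the same change would give a similar step on the core of compound 1.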